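The compounds below may be only part of what the source reports. "The series", "measured", "known", "first", "only" and "open" are said of these compounds alone.

In a functional assay on MDA-MB-231 cells (Homo sapiens) for inhibition, read by sulforhodamine B assay, with a stated time of 74 h (on this read-out lower numbers stand for stronger inhibition and higher numbers for weaker inhibition), the parent compound 1 `Cc1ccc(S(=O)(=O)N2C(=O)COC23C=CC(=O)C=C3)cc1` gives 70 nM. Compound 2 `Cc1ccccc1S(=O)(=O)N1C(=O)COC12C=CC(=O)C=C2` keeps the same atoms joined differently: 2-methylphenyl in place of 4-methylphenyl on a sulfonyl sulfur. Compound 2 reaches only a limit of the assay in this assay, > 10000 nM, and no number. The shift this makes is an at least 140-fold higher number from compound 1 to compound 2 (2.15 log units; beyond the scatter). Compound 3 `O=C1C=CC2(C=C1)OCC(=O)N2S(=O)(=O)c1ccc(OC(F)(F)F)cc1` carries trifluoromethoxy in place of methyl on an aromatic carbon. Compound 3 also reaches only a limit of the assay in this assay, > 10000 nM. Here the shift is an at least 140-fold higher number from compound 1 to compound 3 (2.15 log units; beyond the scatter). Both changes away from compound 1 therefore lead to the limit of > 10000 nM in this assay, at which 2 of the 3 values shown sit, so the true loss in either case could be larger than the step states.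

Compound 4 `O=C1C=CC2(C=C1)OCC(=O)N2S(=O)(=O)c1ccccc1OC(F)(F)F` is still to be measured in this assay. It differs from compound 2 by trifluoromethoxy in place of methyl on an aromatic carbon. Among the compounds with values here, this is the same kind of change as the one from compound 1 to compound 3, but the place is not the same: in compound 3 the trifluoromethoxy stands para to a large group, whereas in compound 4 it stands ortho to a large group. Because compound 2 already sits at > 10000 nM, compound 4 is expected to stay at or beyond the limit. The same kind of change gave an at least 140-fold higher number from compound 1 to compound 3 (2.15 log units; beyond the scatter), and compound 3 itself reaches only a limit of the assay, > 10000 nM. The expected step is a step that the limit leaves unreadable from compound 2 to compound 4, resting on the limit reached by compound 2 and the large loss from compound 1 to compound 3, with the caveat that the change sits in a different place. Compound 4 is therefore estimated at 30000 nM, with a range from 10000 nM to 100000 nM.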

Compound 4, half-maximal inhibitory concentration: > 10000 nM
Compound 4 was reported as a limit (the forecaster's own chance of this, stated with the estimate: 85%); the middle value lies beyond the limit too.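

Compound 2 and compound 4 both stop at a limit of the assay rather than a number in this assay, so the step between them cannot be read: the limit of > 10000 nM in this assay, at which 3 of the 4 values shown sit. The compounds shown leave open how far beyond that limit compound 2, compound 3 and compound 4 truly lie, and whether trifluoromethoxy in place of methyl, ortho to a large group, changes the read-out at all.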